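A few compounds are considered here, and "the series" means these few. Any claim that something is new, unique, unknown or untested is made for them only; others in the source may bear on it.

Working notes on the series.

In a functional assay on the whole organism for inhibition, with Rattus norvegicus as the target, read by paw edema, with stated times of 30 min and 2 h, at a dose of 0.28 mmol/kg by the oral route (a lower number here means less inhibition, a higher number more inhibition at the dose given (going by the name of the read-out)), compound 1 `CC(=O)c1ccc(NC(=O)c2nc(-c3ccccc3)n(-c3ccc(S(N)(=O)=O)cc3)n2)cc1` gives 68%, and compound 2 `COC(=O)c1nc(-c2ccccc2)n(-c2ccc(S(N)(=O)=O)cc2)n1` gives 48%. Within the data shown here, the only step between measured compounds is a number 20 percentage points lower from compound 1 to compound 2 (beyond the scatter). Among the measured compounds shown here, on the two numbers so far, compound 2 stands lowest, with compound 1 the nearer and higher of the pair by a margin beyond the scatter.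

Compound 3 `CC(C)NC(=O)c1nc(-c2ccccc2)n(-c2ccc(S(N)(=O)=O)cc2)n1` is the next member. It differs from compound 2 as follows: isopropylamino in place of methoxy on a carbonyl carbon Cut one bond further out, the change reads methoxycarbonyl to isopropylcarbamoyl, so compound 3 shares with compound 1 a carbamoyl group in place of the ester of compound 2, though with an isopropyl rather than a 4-acetylphenyl substituent on the amide nitrogen.

The bearing step is the single one measured: a number 20 percentage points lower from compound 1 to compound 2 (beyond the scatter), a modest fall when the amide was replaced by the ester. Returning to an amide is therefore expected to recover part of that loss, giving a step of a number 10 percentage points higher from compound 2 to compound 3 (within the scatter) in this assay. For the measured compounds named here, no measured step tells how an isopropyl amide compares with an aryl amide, so the expectation is kept below the level of compound 1. For compound 3 the estimate is 58%, within a range from 44% to 72%.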

Compound 3, a percentage reported as inhibition, in the whole organism at one dose (the size of the read-out at that dose, not a potency): 43%
For compound 3 the middle estimate is 15 percentage points above the measured one; the whole stated range lies above it.
By their numbers in this assay, from the lowest: compounds 3 and 2 (each within the scatter of the next); then compound 1.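

In this assay the change from methoxy to isopropylamino on a carbonyl carbon gives a number 5 percentage points lower from compound 2 to compound 3 (within the scatter), so the amide of compound 3 cannot be told apart from the ester of compound 2 on these numbers. With the amide kept, isopropyl in place of 4-acetylphenyl on the amide-type nitrogen gives a number 25 percentage points lower from compound 1 to compound 3 (beyond the scatter), which ties the higher number of compound 1 to its 4-acetylphenyl group rather than to the amide link alone, as far as these three compounds go. No available evidence bears on why either step has this size.

From the compounds shown here alone, it remains open whether an unsubstituted phenyl, a benzyl or a longer alkyl chain on the amide nitrogen would read with compound 1 or with compound 3, and so whether the acetyl group itself counts or the aromatic ring is enough. A free carboxylic acid or a primary amide on the same carbonyl carbon also lies outside the compounds shown, and a read-out at a single dose leaves potency undefined for all of them.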